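This account rests on a few compounds, and the source may have more. Where it says the series, first, only, none or still open, it means among the compounds named here.

Of the compounds shown here, two have been measured so far in a functional assay on MCF7 cells (Homo sapiens) for cytotoxicity, read by MTT assay, with a stated time of 72 h; a lower number here means a stronger inhibitor, a higher number a weaker inhibitor. Compound 1 `COc1c(OCCCCN2CCN(C)CC2)cc(O)c2c(=O)cc(-c3ccc(F)cc3Br)oc12` gives 3090 nM. Compound 2 `CN(C)CCCOc1c(OCc2ccccc2)cc(O)c2c(=O)cc(-c3ccccc3)oc12` gives 3210 nM in this assay, and that number lies within the usual scatter of the number for compound 1, so the two cannot be told apart on this evidence. Compound 3 `CCN(CC)CCCOc1c(OCc2ccccc2)cc(O)c2c(=O)cc(-c3ccccc3)oc12` has not yet been measured. It differs from compound 2 in one place: diethylamino in place of dimethylamino on a saturated chain carbon, three bonds along the chain from an oxygen on an aromatic ring. Within the data shown here, no pair of measured compounds shows what such a change does here, so there is no measured step to lean on. With the amine kept and only its two small alkyl groups lengthened, the expectation is a step from compound 2 to compound 3 of a 1.1-fold lower number from compound 2 to compound 3 (0.03 log units; within the scatter), that is, nothing beyond the scatter in either direction. Compound 3 is therefore estimated at 3000 nM, with a range from 1200 nM to 7500 nM.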

Compound 3, half-maximal inhibitory concentration: 3210 nM
For compound 3 the middle estimate is 1.1-fold (0.03 log units) below the measured one; the measured number falls inside the stated range.
By their numbers in this assay, from the lowest: compounds 1, 2 and 3 (each within the scatter of the next).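

In this assay, among these compounds, the first measured step at this position gives no change at the digits printed from compound 2 to compound 3 (within the scatter) when diethylamino takes the place of dimethylamino. On the shared core, then, this end of the chain accepts the slightly larger amine with no detectable effect on the read-out, although a single pair cannot show how far that holds. Nothing measured here explains why the number stays level.

From the compounds shown here alone, whether the position is equally undemanding for a different end group remains open, for example a morpholine ring, a piperidine ring or a carboxylic acid in place of the amine. Compound 1 differs from compound 2 and compound 3 in more than one place, so the effect of a longer chain carrying diethylamino also remains unanswered.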